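A few compounds are considered here, and "the series" means these few. Any claim that something is new, unique, unknown or untested is made for them only; others in the source may bear on it.

Values in a functional assay on KB cells (Homo sapiens) for antiproliferative activity, read by MTT assay, with a stated time of 72 h (a higher number here means a weaker inhibitor, a lower number a stronger inhibitor), for the series so far
compound 1 `COc1ccc(-c2ssc(=S)c2-c2cc(OC)c(OC)c(OC)c2)cc1N` gives 327 nM
compound 2 `COc1ccc(-c2c(-c3cc(OC)c(OC)c(OC)c3)ssc2=S)cc1N` gives 2170 nM
compound 3 `COc1ccc(-c2ssc(=O)c2-c2cc(OC)c(OC)c(OC)c2)cc1` gives 324 nM

Compound 3 at 324 nM stands level with compound 1 at 327 nM within the scatter, while compound 2 at 2170 nM lies beyond the scatter on the weaker side of compound 3.

The next entry is compound 4 `COc1ccc(-c2ssc(=O)c2-c2cc(OC)c(OC)c(OC)c2)cc1[N+](=O)[O-]`, which differs from compound 3 in one place: nitro in place of hydrogen on an aromatic carbon that puts nitro in place of hydrogen on an aromatic carbon, ortho to a methoxy group.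

For the measured compounds named here, no two measured compounds differ in one place only, so no measured step speaks directly to this change. Compound 1 carries an amino group on that same carbon, on a different core, and gives 327 nM in this assay as its reading. Compound 2 carries the same amino group and gives 2170 nM on its own core, so the guidance from these two is loose.

A modest rise in the number is expected, and the estimated step of a 2.5-fold higher number from compound 3 to compound 4 (0.39 log units; beyond the scatter) would mean a somewhat weaker inhibitor, only a little beyond the scatter. For compound 4 the expected value is 800 nM with an estimated range of 200 nM to 3200 nM and awaits measurement.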

Compound 4, half-maximal inhibitory concentration: 22300 nM
Compound 4: the middle estimate sits 28-fold (1.45 log units) below what was measured, and the stated range ends below it.
By their numbers in this assay, from the lowest: compounds 3 and 1 (each within the scatter of the next); then compound 2; then compound 4.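

In this assay, for the compounds shown here, nitro in place of hydrogen on this aromatic carbon, ortho to a methoxy group, gives a 69-fold higher number from compound 3 to compound 4 (1.84 log units; beyond the scatter) and is the first step that changes one place only. It shows that this carbon is not indifferent to what it carries: on the core shared by compound 3 and compound 4, the hydrogen-bearing compound is much the stronger inhibitor, and this single change moves the number far beyond the scatter. No measurement shown here bears on what lies behind the size of this step.

From the compounds shown here alone, it remains open whether the loss is particular to nitro or would follow from other groups on this carbon, as the amino group of compound 1 stands on a different core and cannot be read against compound 3 or compound 4 as a single change. An amine on the core of compound 3 would settle that comparison directly, and a hydroxyl group or a fluorine atom on the same carbon would show how far the position accepts anything other than hydrogen.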